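Replacing an Aryl Ether by a Phenethyl Chain

The compounds below may be only part of what the source reports. "The series", "measured", "known", "first", "only" and "open" are said of these compounds alone.

Compound 1 `COc1ccc(Oc2ccc3c(NCCCNCc4cc(F)ccc4OC)ccnc3c2)cc1` gives 7000 nM in an ADME assay on HepG2 cells (Homo sapiens) for cytotoxicity, read by luminescence, CellTiter-Glo and ATP content, with a stated time of 72 h; a lower number here means that less compound is needed, a higher number that more compound is needed for the effect.
Compound 2 `COc1ccc(Oc2ccc3c(NCCCNCc4cccc(OC)c4O)ccnc3c2)cc1` gives 5500 nM.
Compound 3 `COc1ccc(Oc2ccc3c(NCCCNCc4ccco4)ccnc3c2)cc1` gives 5300 nM.

Among these three numbers compound 2 stands second highest, yet the step of a 1.0-fold lower number from compound 2 to compound 3 (0.02 log units; within the scatter) and the step of a 1.3-fold lower number from compound 1 to compound 2 (0.10 log units; within the scatter) are both within the scatter, so the three compounds cannot be told apart. Compound 4 `COc1cccc(CNCCCNc2ccnc3cc(CCc4ccccc4)ccc23)c1O` differs from compound 2 at another part of the molecule: phenethyl in place of 4-methoxyphenoxy on an aromatic carbon. Among the compounds with values here, none of the measured steps touches this position; each of them, including a 1.3-fold lower number from compound 1 to compound 3 (0.12 log units; within the scatter), varies only the group on the saturated chain carbon bound to the amine nitrogen, and all stayed within the scatter. There is thus no measured guide for this change, and no step beyond the scatter is expected, no change at the digits printed from compound 2 to compound 4 (within the scatter). Compound 4 is therefore estimated at 5500 nM, with a range from 2000 nM to 15000 nM.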

Compound 4, half-maximal effective concentration: 6800 nM
Beside the measured number, compound 4's estimate is 1.2-fold (0.09 log units) below it, within the range that was stated.
By their numbers in this assay, from the lowest: compounds 3, 2, 4 and 1 (each within the scatter of the next).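

Phenethyl in place of 4-methoxyphenoxy is the only step shown at this aromatic carbon, and it gives a 1.2-fold higher number from compound 2 to compound 4 (0.09 log units; within the scatter) in this assay. The earlier steps shown here varied only the group on the saturated chain carbon, so this shows that an all-carbon phenethyl group can stand here with the number staying within the scatter. No evidence is available to explain this result.

As far as these compounds go, whether a carboxylic acid, an amine or a longer chain on this aromatic carbon would move the number beyond the scatter remains open. So does whether phenethyl gives the same result when furan-2-yl sits on the saturated chain carbon.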